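Methoxy for tert-butyl on a phenolic enone scaffold

This account rests on a few compounds, and the source may have more. Where it says the series, first, only, none or still open, it means among the compounds named here.

The measured compounds and their values in a functional assay for inhibition, with Oryctolagus cuniculus as the target; on this read-out lower numbers stand for stronger inhibition and higher numbers for weaker inhibition:
compound 1 `CC(=O)/C=C/c1cccc(O)c1O` 1960 nM
compound 2 `CC(=O)/C=C/c1cc(C)ccc1O` 8000 nM
compound 3 `CC(=O)/C=C/c1cc(C(C)(C)C)ccc1O` 8000 nM

Compound 3 stands level with compound 2; together these two give the highest numbers of the three, and compound 1 gives the lowest of them. Within the data shown here, the one measured step that changes a single place is no change at the digits printed from compound 2 to compound 3 (within the scatter), which shows that exchanging a methyl for a tert-butyl at this place leaves the read-out where it was.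

Compound 4 `COc1ccc(O)c(/C=C/C(C)=O)c1` differs from compound 3 by methoxy in place of tert-butyl on an aromatic carbon. The step from compound 2 to compound 3 bears on this change, since it also alters the group at the same aromatic carbon, and it was flat. Compound 1 carries a hydroxy rather than a methoxy and differs in more than one place, so its lower number can only be noted, not transferred. On that basis compound 4 is expected to move by a 1.3-fold lower number from compound 3 to compound 4 (0.12 log units; within the scatter), that is by no step beyond the scatter. The estimate for compound 4 in this assay is 6000 nM, within 2500 nM to 15000 nM.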

Compound 4, half-maximal inhibitory concentration: 3980 nM
Estimate against measurement, compound 4: 1.5-fold (0.18 log units) above; measured number inside the range.
By their numbers in this assay, from the lowest: compound 1; then compounds 4, 2 and 3 (each within the scatter of the next).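

In this assay, the oxygen-linked group at this aromatic carbon gives a 2.0-fold lower number from compound 3 to compound 4 (0.30 log units; within the scatter), and against the smaller carbon group it gives a 2.0-fold lower number from compound 2 to compound 4 (0.30 log units; within the scatter). Together with the flat step between the two carbon groups, this shows that methyl, tert-butyl and methoxy at this carbon, para to the hydroxy group, all read within the scatter of one another, so bringing in an oxygen here does not separate compound 4 from compound 2 or compound 3. Nothing measured here speaks to why the read-out stays this flat.

Still open, going by these compounds, is whether an amine, a carboxylic acid or a longer alkoxy chain at this carbon would move the number beyond the scatter. The compounds shown also do not settle which of its several differences sets apart compound 1, at 1960 nM.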